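A Large Sulfonamide Arm Replaces Cyclopropyl on Compound 2

This account rests on a few compounds, and the source may have more. Where it says the series, first, only, none or still open, it means among the compounds named here.

Compound 1 `O=C1O[C@H]([C@@H](O)Cn2cc(-c3cccc(O)c3)nn2)C(OCc2ccccc2)=C1OCc1ccccc1` carries a 3-hydroxyphenyl group on the five-membered aromatic ring with 3 nitrogen. In a functional assay on SW-620 cells (Homo sapiens) for antiproliferative activity, read by MTT assay, with a stated time of 72 h (on this read-out lower numbers stand for stronger inhibition and higher numbers for weaker inhibition), compound 1 reaches only a limit of the assay, > 100000 nM. Compound 2 `O=C1O[C@H]([C@@H](O)Cn2cc(C3CC3)nn2)C(OCc2ccccc2)=C1OCc1ccccc1`, in which cyclopropyl replaces that group, gives 54200 nM in this assay. Within the data shown here, this is the only number obtained here. The result for compound 1 is a limit (the limit of > 100000 nM in this assay, at which 1 of the 2 values shown sits). The measured change is an at least 1.8-fold lower number from compound 1 to compound 2 (0.26 log units; that floor lies within the scatter), a step whose floor does not exceed the scatter, so the two compounds are not separated with confidence.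

Compound 3 `Cc1ccc(S(=O)(=O)NCc2cn(C[C@H](O)[C@H]3OC(=O)C(OCc4ccccc4)=C3OCc3ccccc3)nn2)cc1` is built from compound 2 by the change ((((4-methylphenyl)sulfonyl)amino)methyl in place of cyclopropyl on an aromatic carbon). Among the measured compounds shown here, the only measured step that bears on this position, from compound 1 to compound 2, exchanged an aryl group for cyclopropyl and moved the read-out by an at least 1.8-fold lower number from compound 1 to compound 2 (0.26 log units; that floor lies within the scatter). With so little to go on, a step beyond the scatter in this assay is not expected, only a wide uncertainty that reaches the limit of the assay. Compound 3 is therefore estimated at 55000 nM, between 15000 nM and 200000 nM, an expected step of a 1.0-fold higher number from compound 2 to compound 3 (0.01 log units; within the scatter).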

Compound 3, half-maximal inhibitory concentration: 45800 nM
For compound 3 the middle estimate is 1.2-fold (0.08 log units) above the measured one; measured number inside the range.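

In this assay, the aromatic carbon of the five-membered aromatic ring with 3 nitrogen accepts a much larger substituent without a separable difference from cyclopropyl: the exchange for (((4-methylphenyl)sulfonyl)amino)methyl gives a 1.2-fold lower number from compound 2 to compound 3 (0.07 log units; within the scatter). Set against the 3-hydroxyphenyl group, the same substituent gives the first step at this position that clears the scatter, an at least 2.1-fold lower number from compound 1 to compound 3 (0.33 log units; beyond the scatter). The result for compound 1 is a limit and not a number, so this step has a floor and no true size: the limit of > 100000 nM in this assay, at which 1 of the 3 values shown sits.

The compounds shown leave open whether an amine or a carboxylic acid on this carbon would move the read-out beyond the scatter from compound 2, since neither cyclopropyl nor the far larger sulfonyl substituent does so. They also leave open which part of the substituent, the sulfonyl amino link or the 4-methylphenyl ring, carries the difference from compound 1.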